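Acyl variation in the amide series: compound 4

The source may report more compounds than this note shows. Statements on the series, on what has been measured and on what is new or still open speak of the compounds shown alone.

Three amides on a shared core have been measured in a functional assay (Sus scrofa) with sulfonylurea receptors; K-ATP channels (Homo sapiens) as the target; on this read-out lower numbers stand for an effect already at smaller amounts and higher numbers for an effect only at larger amounts of compound. Compound 1 `CC(=O)Nc1c(C(O)(C(F)(F)F)C(F)(F)F)ccc2ccccc12` gives 95.5 nM, compound 2 `O=C(Nc1c(C(O)(C(F)(F)F)C(F)(F)F)ccc2ccccc12)C1CC1` gives 126 nM, and compound 3 `COCC(=O)Nc1c(C(O)(C(F)(F)F)C(F)(F)F)ccc2ccccc12` gives 204 nM. Compound 3 thus stands at the highest of the three numbers; the step of a 1.6-fold higher number from compound 2 to compound 3 (0.21 log units; within the scatter) lies within the scatter, and the step of a 2.1-fold higher number from compound 1 to compound 3 (0.33 log units; beyond the scatter) is a modest one beyond it. Across the acyl groups the numbers move little, as a 1.3-fold higher number from compound 1 to compound 2 (0.12 log units; within the scatter) also shows.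

Compound 4 `O=C(Nc1c(C(O)(C(F)(F)F)C(F)(F)F)ccc2ccccc12)c1ccco1` carries the change (furan-2-yl in place of methoxymethyl on a carbonyl carbon). Going by the values given here, none of the measured steps places an aromatic ring on the carbonyl carbon; the nearest comparisons are the exchanges of one acyl group for another in a 1.6-fold higher number from compound 2 to compound 3 (0.21 log units; within the scatter) and a 1.3-fold higher number from compound 1 to compound 2 (0.12 log units; within the scatter), both within the scatter, and the single modest step of a 2.1-fold higher number from compound 1 to compound 3 (0.33 log units; beyond the scatter). On that basis a step of about scatter size is expected in this assay, if anything toward a lower number, because compound 3 holds 204 nM as the highest of the three. For compound 4 the expected step is a 1.6-fold lower number from compound 3 to compound 4 (0.20 log units; within the scatter). The estimate for compound 4 is 130 nM, with a range from 45 nM to 400 nM.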

Compound 4, half-maximal effective concentration: 182 nM
For compound 4 the middle estimate is 1.4-fold (0.15 log units) below the measured one; the range from low to high includes it.
By their numbers in this assay, from the lowest: compounds 1, 2, 4 and 3 (each within the scatter of the next, the first and the last beyond it).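

Notes on the acyl position: in this assay, furan-2-yl on the carbonyl carbon gives a 1.1-fold lower number from compound 3 to compound 4 (0.05 log units; within the scatter), along with a 1.4-fold higher number from compound 2 to compound 4 (0.16 log units; within the scatter) and a 1.9-fold higher number from compound 1 to compound 4 (0.28 log units; within the scatter), so all three new steps stay within the scatter. This position, on a carbonyl carbon whose other neighbour is the amide-type nitrogen, therefore carries a five-membered aromatic ring without a step beyond the scatter from any earlier compound, which the methyl, cyclopropyl and methoxymethyl amides could not show. Going by these compounds alone, the only step beyond the scatter remains a 2.1-fold higher number from compound 1 to compound 3 (0.33 log units; beyond the scatter), and compound 4 lies within the scatter of both of those compounds; no available data explain why the numbers stay so close.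

Going by these compounds, it remains open whether a phenyl ring, a furan-3-yl group or a furan-2-yl ring bearing a further substituent would stay within the same narrow band. Equally open, on these data alone, is whether an amine, a carboxylic acid or a longer alkyl chain on the same carbonyl carbon would produce a step clearly beyond the scatter.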